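A few compounds are considered here, and "the series" means these few. Any claim that something is new, unique, unknown or untested is made for them only; others in the source may bear on it.

Compound 1 `Nc1nc(C(F)(F)F)cc2c1[nH]c(=O)n2Cc1ccc(NCc2ccccc2)nc1` is the reference point of this series. In an in vitro ADME assay on microsomes from liver (Homo sapiens) for pharmacokinetics (on this read-out lower numbers stand for slow clearance and higher numbers for fast clearance), compound 1 gives < 8 mL.min-1.g-1, which is a limit of the assay rather than a number, as recorded in the limit of < 8 mL.min-1.g-1 in this assay, at which 1 of the 3 values shown sits. Two analogues give numbers: compound 2 `CN(CCN1CCCCC1)c1ccc(Cn2c(=O)[nH]c3c(N)nc(C(F)(F)F)cc32)cn1` gives 25 mL.min-1.g-1, and compound 3 `CN(C)CCNc1ccc(Cn2c(=O)[nH]c3c(N)nc(C(F)(F)F)cc32)cn1` gives 9 mL.min-1.g-1. Compound 4 `CN1CCN(CCN(C)c2ccc(Cn3c(=O)[nH]c4c(N)nc(C(F)(F)F)cc43)cn2)CC1` differs from compound 1 in one place: methyl(2-(4-methylpiperazin-1-yl)ethyl)amino in place of benzylamino on an aromatic carbon. The step that bears most directly on this change is an at least 3.1-fold higher number from compound 1 to compound 2 (0.49 log units; beyond the scatter), where a ring-bearing chain of the same kind took the same position. The step of a 2.8-fold lower number from compound 2 to compound 3 (0.44 log units; beyond the scatter) shows a smaller amine-bearing chain pulling the number back down, and an at least 1.1-fold higher number from compound 1 to compound 3 (0.05 log units; that floor lies within the scatter) leaves only a floor within the scatter. Because of an at least 3.1-fold higher number from compound 1 to compound 2 (0.49 log units; beyond the scatter) the number for compound 4 is expected to rise from the floor of compound 1. Compound 4 is expected to show an at least 1.7-fold higher number from compound 1 to compound 4 (0.24 log units; that floor lies within the scatter). Compound 4 is therefore estimated at 14 mL.min-1.g-1, with a range of 6 mL.min-1.g-1 to 30 mL.min-1.g-1.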

Compound 4, intrinsic clearance in microsomes: 25 mL.min-1.g-1
Compound 4: the middle estimate sits 1.8-fold (0.25 log units) below what was measured, and the stated range covers the measured number.
By their numbers in this assay, from the lowest: compound 3; then compounds 2 and 4 (each within the scatter of the next). At a limit, below all of these: compound 1.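

In this assay, the end of the chain made no visible difference at this position: with 4-methylpiperazin-1-yl in place of piperidin-1-yl, the result is no change at the digits printed from compound 2 to compound 4 (within the scatter). The rise seen with the methyl(2-(piperidin-1-yl)ethyl)amino chain therefore recurs with the methyl(2-(4-methylpiperazin-1-yl)ethyl)amino chain, as an at least 3.1-fold higher number from compound 1 to compound 4 (0.49 log units; beyond the scatter), while the (2-(dimethylamino)ethyl)amino chain stays apart, with a 2.8-fold higher number from compound 3 to compound 4 (0.44 log units; beyond the scatter). The step from the reference remains a floor, as compound 1 holds a limit and not a number: the limit of < 8 mL.min-1.g-1 in this assay, at which 1 of the 4 values shown sits.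

The compounds shown leave open which part of the chain carries the step from compound 3: the methyl on the chain nitrogen or the ring at its end. They also do not tell how a morpholine at the chain end, or a longer chain, would read in this assay.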